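A few compounds are considered here, and "the series" means these few. Any claim that something is new, unique, unknown or untested is made for them only; others in the source may bear on it.

Working notes on the series. In an assay for inhibition of DNA topoisomerase 1 (Homo sapiens), with a stated time of 30 min, tested at 100 uM (on this read-out lower numbers stand for a weaker effect and higher numbers for a stronger effect at the one concentration tested), compound 1 `O=C(/C=C/c1ccco1)c1ccccc1OCC1CO1` gives 36.8%, compound 2 `O=C(/C=C/c1cccs1)c1ccccc1OCC1CO1` gives 11.1% and compound 3 `O=C(/C=C/c1ccco1)c1cccc(OCC2CO2)c1` gives 28.5%. Among the compounds with values here, compound 3 thus stands within the scatter of compound 1 on this assay, while its number lies beyond the scatter above that of compound 2; no step is computed between compound 3 and either of them.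

Compound 4 `O=C(/C=C/c1cccs1)c1cccc(OCC2CO2)c1` has not yet been measured in this assay. It differs from compound 3 in one place: thiophen-2-yl in place of furan-2-yl on a double-bonded chain carbon bound to a double-bonded chain carbon. Within the data shown here, the only measured step that bears on this change is a number 25.7 percentage points lower from compound 1 to compound 2 (beyond the scatter), the same swap made on the core of compound 1. Carried over to compound 3, a step of similar size and the same direction is expected, giving a number 23.5 percentage points lower from compound 3 to compound 4 (beyond the scatter) in this assay. On that basis compound 4 is estimated to show 5% in this assay, with a range from -5% to 20%, a single carried-over step being a thin basis.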

Compound 4, a percentage reported as inhibition, at one concentration (the size of the read-out at that concentration, not a potency): 2.7%
Compound 4: the middle estimate sits 2.3 percentage points above what was measured; the range from low to high includes it.
By their numbers in this assay, from the lowest: compounds 4 and 2 (each within the scatter of the next); then compounds 3 and 1 (each within the scatter of the next).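

In this assay, thiophen-2-yl in place of furan-2-yl on a double-bonded chain carbon bound to a double-bonded chain carbon now reads on a second core, with a number 25.8 percentage points lower from compound 3 to compound 4 (beyond the scatter). Until now this change rested on a single pair of compounds, so a step tied to the core of compound 1 could not be ruled out. Across these two cores the change carries over with practically the same size and the same direction: the same change on two cores in this assay, a number 25.7 percentage points lower (beyond the scatter) from compound 1 to compound 2 and a number 25.8 percentage points lower (beyond the scatter) from compound 3 to compound 4, 0.1 percentage points apart, within the scatter of two such steps

As far as these compounds go, whether a phenyl group or a pyridin-2-yl ring at this place would read nearer the furan-2-yl or the thiophen-2-yl compounds stays open, and two cores cannot show how far the step extends to others. All numbers are read-outs at one concentration, so they show only a stronger or weaker effect at that concentration.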